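This account rests on a few compounds, and the source may have more. Where it says the series, first, only, none or still open, it means among the compounds named here.

Working notes on the series. Compound 2 `Cc1cccc(N2C(=O)[C@H]3[C@H](ON4[C@@H]3C(=O)N(C)[C@@]43C[C@H](C)CC[C@H]3C(C)C)C2=O)c1` carries 3-methylphenyl on an amide-type nitrogen in a ring of the shared core. Among the compounds with values here, in a functional assay, with a stated time of 20 min, tested at 0.5 mg/mL (a lower number here means a weaker effect, a higher number a stronger effect of the compound at the concentration tested), compound 2 gives 26.8%, the highest of the two numbers so far, but its only neighbour sits within the scatter of it: compound 1 `CC(C)[C@@H]1CC[C@@H](C)C[C@@]12N(C)C(=O)[C@@H]1[C@H]3C(=O)N(c4ccc(Cl)cc4)C(=O)[C@H]3ON12`, with 4-chlorophenyl at the same position, gives in this assay 18.1%. Within the data shown here, the one measured step at this position is a number 8.7 percentage points higher from compound 1 to compound 2 (within the scatter), so a change of the aromatic group here has not yet moved the read-out beyond the scatter.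

Compound 3 `Cc1ccc(N2C(=O)[C@H]3[C@H](ON4[C@@H]3C(=O)N(C)[C@@]43C[C@H](C)CC[C@H]3C(C)C)C2=O)c(C)c1` differs from compound 2 in one place: 2,4-dimethylphenyl in place of 3-methylphenyl on an amide-type nitrogen in a ring. Among the measured compounds shown here, the only step that bears on this change is the exchange of the aryl group on the same nitrogen from compound 1 to compound 2, and that step was within the scatter. With a single such comparison, no step beyond the scatter is expected in this assay; the expected step is a number 0.2 percentage points higher from compound 2 to compound 3 (within the scatter). For compound 3 the estimate in this assay is 27%, with a range from 12% to 42%.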

Compound 3, a percentage reported as activity, at one concentration (the size of the read-out at that concentration, not a potency): 49.9%
Compound 3: the middle estimate sits 22.9 percentage points below what was measured, outside the stated range (above it).
By their numbers in this assay, from the lowest: compounds 1 and 2 (each within the scatter of the next); then compound 3.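

Exchanging the aryl group on the amide-type nitrogen can move the read-out beyond the scatter in this assay: 2,4-dimethylphenyl in place of 3-methylphenyl gives a number 23.1 percentage points higher from compound 2 to compound 3 (beyond the scatter), and 2,4-dimethylphenyl in place of 4-chlorophenyl gives a number 31.8 percentage points higher from compound 1 to compound 3 (beyond the scatter). The earlier step between the two singly substituted aryl groups stayed within the scatter, so this position is not indifferent to its aryl group, and among the three compounds shown compound 3 stands clear of both others, with one more carbon in the entering group than in 3-methylphenyl. Nothing measured on these compounds accounts for the size of this step.

The compounds shown leave open whether the rise goes with the second methyl group as such or with the whole 2,4-dimethylphenyl group, and whether it would hold for an unsubstituted phenyl, a methoxyphenyl or a saturated cyclohexyl on the same nitrogen. With one read-out at a single concentration, they also leave open how the effects of the three compounds would compare at other concentrations.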